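Swapping the aryl group on the piperazine: compound 4

The compounds below may be only part of what the source reports. "The series", "measured", "known", "first", "only" and "open" are said of these compounds alone.

Measured compounds:
- compound 1, `O=C(Nc1ccc2[nH]c(=O)oc2c1)C(=O)N1CCN(c2ccc(Cl)cc2)CC1`: 7.2 mL/min/kg
- compound 2, `O=C(Nc1ccc2[nH]c(=O)oc2c1)C(=O)N1CCN(c2ccc(F)cc2)CC1`: 11.1 mL/min/kg
- compound 3, `O=C(Nc1ccc2[nH]c(=O)oc2c1)C(=O)N1CCN(c2cc(F)cc(F)c2)CC1`: "not determined" (no result reported)

Among the measured compounds shown here, in an ADME assay on the whole organism (Rattus norvegicus, strain Sprague-Dawley) for pharmacokinetics, using cassette dosing, at a dose of 0.5 mg/kg by the intravenous route (on this read-out higher numbers stand for fast clearance and lower numbers for slow clearance), compound 1 gives 7.2 mL/min/kg and compound 2 gives 11.1 mL/min/kg; the one step between them, a 1.5-fold higher number from compound 1 to compound 2 (0.19 log units; within the scatter), is the only measured step in the set. Compound 3 stands nowhere on these numbers: in this assay compound 3 gives "not determined" (no result reported), so there is no value to start from.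

Compound 4, `COc1ccc(N2CCN(C(=O)C(=O)Nc3ccc4[nH]c(=O)oc4c3)CC2)cc1F`, differs from compound 3 in one place: 3-fluoro-4-methoxyphenyl in place of 3,5-difluorophenyl on an amine nitrogen in a ring.

For the measured compounds named here, the single measured step, a 1.5-fold higher number from compound 1 to compound 2 (0.19 log units; within the scatter), exchanges one halogen for another on the aromatic ring at this same position and stays within the scatter. Going by the values given here, it says nothing directly about adding a methoxy group, and no measured pair mirrors the present change. Among the compounds with values here, with only two measured values, both of slow-to-moderate clearance in this assay, and the starting point for compound 3 unknown, the expectation for compound 4 is no step that can be separated from the scatter, set around the middle of what compounds 1 and 2 show.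

Compound 4 is therefore estimated at 9 mL/min/kg in this assay, with a range from 4 mL/min/kg to 20 mL/min/kg.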

Compound 4, clearance: 101 mL/min/kg
Beside the measured number, compound 4's estimate is 11-fold (1.05 log units) below it; measured number above the stated range.
By their numbers in this assay, from the lowest: compounds 1 and 2 (each within the scatter of the next); then compound 4.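

The aryl group on an amine nitrogen in a ring proves able to move the read-out in this assay well beyond the scatter: 3-fluoro-4-methoxyphenyl in place of 4-fluorophenyl gives a 9.1-fold higher number from compound 2 to compound 4 (0.96 log units; beyond the scatter) and in place of 4-chlorophenyl gives a 14-fold higher number from compound 1 to compound 4 (1.15 log units; beyond the scatter) while the halogen exchange alone, a 1.5-fold higher number from compound 1 to compound 2 (0.19 log units; within the scatter) had shown no change that could be told from the scatter. The direct step from compound 3 to compound 4 cannot be read, as compound 3 has no number, so the size of the change rests on compound 1 and compound 2 alone. Nothing measured here accounts for the higher clearance of compound 4.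

The compounds shown leave open whether the rise follows the methoxy group by itself or needs the fluorine with it, which a 4-methoxyphenyl group would separate. They also leave open where a 4-ethoxyphenyl or 4-hydroxyphenyl group on the same nitrogen would stand in this assay and where the 3,5-difluorophenyl group of compound 3 falls.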